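This account rests on a few compounds, and the source may have more. Where it says the series, first, only, none or still open, it means among the compounds named here.

Measured compounds:
- compound 1 `O=C(OCc1ccccc1)N1CCN(C(=S)SCc2cn(Cc3ccc(F)cc3)nn2)CC1`: 10300 nM in a functional assay on MCF7 cells (Homo sapiens) for inhibition, read by MTT assay, with a stated time of 72 h; on this read-out lower numbers stand for stronger inhibition and higher numbers for weaker inhibition
- compound 2 `S=C(SCc1cn(Cc2ccc(Cl)c(Cl)c2)nn1)N1CCNCC1`: "not determined" (no result reported) in this assay
- compound 3 `O=C(OCc1ccccc1)N1CCN(C(=S)SCc2cn(Cc3ccc(Cl)c(Cl)c3)nn2)CC1`: 10600 nM in this assay

Compound 2 stands without a number in this assay; nothing measured can be said of where it sits. Compound 4 `Fc1ccc(Cn2cc(CSC(=S)N3CCNCC3)nn2)cc1` is not yet measured and differs from compound 2 in one place: 4-fluorophenyl in place of 3,4-dichlorophenyl on a saturated chain carbon bound to an aromatic nitrogen.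

Among the measured compounds shown here, the only measured step that bears on this change is the same exchange taken the other way, on the pair that carries the core of compound 1 rather than that of compound 2: a 1.0-fold higher number from compound 1 to compound 3 (0.01 log units; within the scatter). That step lay within the scatter, so the exchange of 3,4-dichlorophenyl for 4-fluorophenyl on a saturated chain carbon bound to an aromatic nitrogen gave no movement in this assay there. For the measured compounds named here, no step joins the core of compound 1 to the core of compound 2, and compound 2 itself has no value, so the level of compound 4 can only be anchored on compounds 1 and 3, and the reach of that anchor is uncertain.

For compound 4 in this assay no step beyond the scatter is expected from the aryl exchange itself; its level is estimated near that of compound 1 at 10300 nM, giving an expected 10000 nM with a range from 3000 nM to 35000 nM.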

Compound 4, half-maximal inhibitory concentration: 49900 nM
Compound 4: the middle estimate sits 5.0-fold (0.70 log units) below what was measured; measured number above the stated range.
By their numbers in this assay, from the lowest: compounds 1 and 3 (each within the scatter of the next); then compound 4.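

Exchanging benzyloxycarbonyl for hydrogen on the amine nitrogen in the ring gives, in this assay, a 4.8-fold higher number from compound 1 to compound 4 (0.69 log units; beyond the scatter), so inhibition weakens when benzyloxycarbonyl is lost from this position. The earlier compounds showed only the aryl exchange, a 1.0-fold higher number from compound 1 to compound 3 (0.01 log units; within the scatter), which stayed within the scatter; this is the first step in the series shown to lie beyond it, and it places the first measurable change at the ring nitrogen rather than on the aryl group. No measurement at hand accounts for this step.

From the compounds shown here alone, the step between compound 2 and compound 4 cannot be read, so whether the aryl exchange also makes no difference with hydrogen on the ring nitrogen remains open. Also open, going by these compounds, is which part of benzyloxycarbonyl the step depends on, a question that an acetyl group or a plain benzyl group on that nitrogen would help to separate.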